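The source may report more compounds than this note shows. Statements on the series, on what has been measured and on what is new or still open speak of the compounds shown alone.

Compound 1 `Cc1nc(SCC(=O)Nc2nc(-c3ccc(Cl)cc3)cs2)n(Nc2ccccc2)c1C`: 3250 nM
Compound 2 `Cc1ccc(Nn2c(SCC(=O)Nc3nc(-c4ccccc4)cs3)nc(C)c2C)cc1`: 2660 nM

Both numbers come from a functional assay on MDA-MB-435 cells (Homo sapiens) for antiproliferative activity, read by sulforhodamine B assay, with a stated time of 48 h; a higher number here means a weaker inhibitor of growth, a lower number a stronger inhibitor of growth. Compound 1 has the higher number of the two, but its value and that of compound 2 lie within the usual scatter of repeated measurements of this kind, so the two cannot be told apart on these data.

Compound 3 `COc1ccc(Nn2c(SCC(=O)Nc3nc(-c4ccc(Cl)cc4)cs3)nc(C)c2C)cc1` has not yet been measured in this assay. It differs from compound 1 in one place: methoxy in place of hydrogen on an aromatic carbon. Among the compounds with values here, no pair of measured compounds shows what this particular change does. Compound 2 carries a different small group on the same ring, together with a second change elsewhere, and its number stays close to that of compound 1; that is the only hint at hand. The step of a 1.1-fold lower number from compound 1 to compound 3 (0.05 log units; within the scatter) is therefore expected to be small, in no firm direction, and probably not beyond the scatter. Compound 3 is estimated at 2900 nM, with a range from 1200 nM to 7000 nM.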

Compound 3, concentration for 50% growth inhibition: 3220 nM
Estimate against measurement, compound 3: 1.1-fold (0.05 log units) below, and the stated range covers the measured number.
By their numbers in this assay, from the lowest: compounds 2, 3 and 1 (each within the scatter of the next).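

In this assay, within the data shown here, compound 1 and compound 3 form the first pair that isolates methoxy in place of hydrogen at this position, para to a large group, and the step of a 1.0-fold lower number from compound 1 to compound 3 (0.00 log units; within the scatter) places the two numbers within the scatter of each other. In this single pair, the anilino and (4-methoxyphenyl)amino versions of the core therefore cannot be told apart, so this position carries a methoxy with no measurable difference in growth inhibition. No separate measurement on these compounds bears on this result.

A single neutral group says little about the position as a whole, so a carboxylic acid or a dimethylamino group in the same place could still read differently. From the compounds shown here alone, whether the same holds on the core of compound 2, which lacks the chlorine, also remains open.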